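The source may hold more compounds than are shown below. What is called first, only, known or untested is meant among the compounds shown, and "the series" means these compounds.

Measured so far in a functional assay, read by spectrophotometry, tested at 100 uM; a lower number here means a stronger inhibitor, a higher number a weaker inhibitor:
- compound 1 `O=C(/C=C/c1cccc2ccccc12)c1cccc(NC(=O)c2cc(-c3ccncc3)n[nH]2)c1` - 64500 nM
- compound 2 `Cc1ccc(/C=C/C(=O)c2cccc(NC(=O)c3cc(-c4ccncc4)n[nH]3)c2)cc1` - 69400 nM
- compound 3 `O=C(/C=C/c1ccc(Cl)cc1)c1cccc(NC(=O)c2cc(-c3ccncc3)n[nH]2)c1` - 63900 nM

Compound 3 stands level with the other two, with a 1.0-fold lower number from compound 1 to compound 3 (0.00 log units; within the scatter) and a 1.1-fold lower number from compound 2 to compound 3 (0.04 log units; within the scatter) as its steps. Compound 4 `O=C(/C=C/c1ccco1)c1cccc(NC(=O)c2cc(-c3ccncc3)n[nH]2)c1` has furan-2-yl in place of 4-chlorophenyl on a double-bonded chain carbon bound to a double-bonded chain carbon. Two measured changes at this same place, a 1.1-fold higher number from compound 1 to compound 2 (0.03 log units; within the scatter) and a 1.0-fold lower number from compound 1 to compound 3 (0.00 log units; within the scatter), stayed within the scatter. Neither brings in a five-membered aromatic ring with 1 hetero atom, so the support is indirect. No shift beyond the scatter and no direction is expected in this assay, the expected step being a 1.0-fold higher number from compound 3 to compound 4 (0.01 log units; within the scatter). Compound 4 is estimated at 65000 nM, with an expected range from 35000 nM to 100000 nM.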

Compound 4, half-maximal inhibitory concentration: 41800 nM
For compound 4 the middle estimate is 1.6-fold (0.19 log units) above the measured one, and the stated range covers the measured number.
By their numbers in this assay, from the lowest: compounds 4, 3, 1 and 2 (each within the scatter of the next).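

In this assay, a five-membered aromatic ring with 1 hetero atom at this position still gives steps within the scatter (a 1.5-fold lower number from compound 3 to compound 4 (0.18 log units; within the scatter); a 1.7-fold lower number from compound 2 to compound 4 (0.22 log units; within the scatter); a 1.5-fold lower number from compound 1 to compound 4 (0.19 log units; within the scatter)). Furan-2-yl therefore sits level with 4-chlorophenyl, 4-methylphenyl and naphthalen-1-yl, and no preference among these rings can be read at this place. Nothing on hand bears on why these values sit level.

Among these compounds, every group at this place so far is an aromatic ring. Open, as far as these compounds go, is whether an amine, a carboxylic acid or a longer chain there would move the number beyond the scatter.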